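This account rests on a few compounds, and the source may have more. Where it says the series, first, only, none or still open, it means among the compounds named here.

Measured so far:
- Compound 1 `O=C(CCCCCCn1cc(C(=O)NCc2ccc(Cl)cc2)c2ccccc21)NO`: 72900 nM
- Compound 2 `O=C(CCCCCCn1cc(C(=O)Nc2ccc(Cl)cc2Cl)c2ccccc21)NO`: 10500 nM

Within the data shown here, in a functional assay on HL-60 cells (Homo sapiens) for antiproliferative activity, read by WST assay, with a stated time of 72 h (a higher number here means a weaker inhibitor, a lower number a stronger inhibitor), compound 2 gives 10500 nM, the lower of the two numbers so far. Compound 3 `O=C(CCCCCCn1cc(C(=O)NC2CCCCC2)c2ccccc21)NO` has not yet been measured. It differs from compound 2 by cyclohexyl in place of 2,4-dichlorophenyl on an amide-type nitrogen. Among the measured compounds shown here, the only measured step bearing on this is a 6.9-fold lower number from compound 1 to compound 2 (0.84 log units; beyond the scatter), which is modest but beyond the scatter. For the measured compounds named here, no measured compound carries cyclohexyl there. Taking the size of a 6.9-fold lower number from compound 1 to compound 2 (0.84 log units; beyond the scatter) as a guide, a similarly modest rise is expected in this assay. The expected change is a 2.4-fold higher number from compound 2 to compound 3 (0.38 log units; beyond the scatter). For compound 3, the estimated value is 25000 nM, with an expected range of 7000 nM to 80000 nM.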

Compound 3, half-maximal inhibitory concentration: 8500 nM
Beside the measured number, compound 3's estimate is 2.9-fold (0.47 log units) above it; low and high end bracket the measured number.
By their numbers in this assay, from the lowest: compounds 3 and 2 (each within the scatter of the next); then compound 1.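

In this assay, replacing an aromatic ring with a saturated one on the amide-type nitrogen gives a 1.2-fold lower number from compound 2 to compound 3 (0.09 log units; within the scatter), so among these compounds the number does not depend on the aromatic ring or its two chlorines. Cyclohexyl in place of 4-chlorobenzyl gives an 8.6-fold lower number from compound 1 to compound 3 (0.93 log units; beyond the scatter), which sets compound 1 apart from both compounds that carry their ring directly on that nitrogen. No supporting evidence accounts for either step. The compounds shown leave open whether a smaller cyclopropyl group or a piperidine ring would hold the number. They also leave open how an unsubstituted phenyl would compare with compound 2.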